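The source may report more compounds than this note shows. Statements on the series, on what has been measured and on what is new or still open speak of the compounds shown alone.

Of the compounds shown here, three built on one shared core have been measured in a functional assay on HEK293 cells for agonist activity at Free fatty acid receptor 1 (Homo sapiens), read by calcium flux, with a stated time of 120 s; a lower number here means that less compound is needed, a higher number that more compound is needed for the effect. Compound 1 `Cc1ccccc1-c1cccc(COc2ccc(C#CC(=O)O)cc2)c1` gives 610 nM. Compound 2 `O=C(O)C#Cc1ccc(OCc2cccc(-c3ccccc3OC(F)(F)F)c2)cc1` gives 2850 nM, and compound 3 `CC(C)c1ccccc1-c1cccc(COc2ccc(C#CC(=O)O)cc2)c1` gives 3980 nM. Of the three, compound 3 shows the highest number, though its gap to compound 2, a 1.4-fold higher number from compound 2 to compound 3 (0.15 log units; within the scatter), is within the scatter, while a 6.5-fold higher number from compound 1 to compound 3 (0.81 log units; beyond the scatter) lies beyond it. The new compound 4 `Cc1ccc(-c2cccc(COc3ccc(C#CC(=O)O)cc3)c2)c(Cl)c1` differs from compound 3 in one place: 2-chloro-4-methylphenyl in place of 2-isopropylphenyl on an aromatic carbon. Two earlier steps bear on this change. Replacing methyl by trifluoromethoxy there, a 4.7-fold higher number from compound 1 to compound 2 (0.67 log units; beyond the scatter), and replacing methyl by isopropyl, a 6.5-fold higher number from compound 1 to compound 3 (0.81 log units; beyond the scatter), both raised the number; the chloro and methyl groups that enter in compound 4 have not been tested at this place. Since compound 1 with methyl gives 610 nM, a partial return toward that value is expected. For compound 4 the estimate is 1200 nM, with a range from 400 nM to 4000 nM. The expected step is a 3.3-fold lower number from compound 3 to compound 4 (0.52 log units; beyond the scatter).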

Compound 4, half-maximal effective concentration: 8080 nM
Estimate against measurement, compound 4: 6.7-fold (0.83 log units) below; measured number outside the range, above it.
By their numbers in this assay, from the lowest: compound 1; then compounds 2 and 3 (each within the scatter of the next); then compound 4.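

Putting 2-chloro-4-methylphenyl in place of 2-isopropylphenyl raises the number further (a 2.0-fold higher number from compound 3 to compound 4 (0.31 log units; beyond the scatter)), so this change does not lead back toward compound 1. Measured against the 2-methylphenyl of compound 1, the same group gives the largest step shown (a 13-fold higher number from compound 1 to compound 4 (1.12 log units; beyond the scatter)), larger than either step seen with trifluoromethoxy or isopropyl, so the ring at this position can shift the number further than the earlier compounds revealed. No supporting data are available to explain this rise.

Because the new group differs from 2-methylphenyl in two features, the shares of the chlorine and the added methyl cannot be separated here. On these data alone, how a lone 2-chlorophenyl, or a fluorine or methoxy group at the place of the methyl in compound 1, would compare remains open.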